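Amino for cyano on a toll-like receptor 8 inhibitor

This account rests on a few compounds, and the source may have more. Where it says the series, first, only, none or still open, it means among the compounds named here.

Within the data shown here, compound 1 `N#Cc1c(Cl)cccc1Oc1ccc(-c2nnco2)cc1` is the only compound of this set with a numerical result: in an assay on HEK293 cells for inhibition of Toll-like receptor 8 (Homo sapiens), with a stated time of 16 h (a lower number here means a stronger inhibitor, a higher number a weaker inhibitor), compound 1 gives 1400 nM. Compound 2 `O=C(Nc1ccc(Oc2cc(C(F)(F)F)cc(C(F)(F)F)c2)cc1)c1c(F)cccc1C(F)(F)F` and compound 3 `O=C(Nc1ccc(Oc2cc(C(F)(F)F)cc(C(F)(F)F)c2)cc1)c1c(O)cccc1F` belong to a different chemotype; for compound 2 the outcome in this assay is "not determined" (no result reported), and for compound 3 it is likewise "not determined" (no result reported), so neither offers a point of comparison. Compound 4 `Nc1c(Cl)cccc1Oc1ccc(-c2nnco2)cc1` differs from compound 1 by a single change, (amino in place of cyano on an aromatic carbon). Among the measured compounds shown here, no measured pair in the set shows what this exchange does, so the expectation rests on compound 1 alone. The step from compound 1 to compound 4 is expected to be a modest weakening, a 2.5-fold higher number from compound 1 to compound 4 (0.40 log units; beyond the scatter), somewhat beyond the scatter. For compound 4 an estimated value of 3500 nM is expected, within a range from 1000 nM to 12000 nM.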

Compound 4, half-maximal inhibitory concentration: 5290 nM
Compound 4: middle estimate off by 1.5-fold (0.18 log units), on the low side; low and high end bracket the measured number.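

Placing amino instead of cyano on this aromatic carbon, ortho to a chloro group, gives in this assay a 3.8-fold higher number from compound 1 to compound 4 (0.58 log units; beyond the scatter) and thus weakens inhibition, yet compound 4 keeps a measurable value. At this position, then, the cyano group is not required for activity, although compound 1 remains the stronger inhibitor. Nothing measured here bears on the reason for this difference. From the compounds shown here alone, it remains open how a hydroxyl, a methyl or a carboxylic acid would fare at this carbon. Going by these compounds, whether the exchange behaves alike without the chloro group also remains open.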